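The compounds below may be only part of what the source reports. "The series", "measured", "known", "first", "only" and "open" are said of these compounds alone.

In a functional assay on MCF7 cells (Homo sapiens) for inhibition, read by trypan blue exclusion, with a stated time of 3 days (a higher number here means a weaker inhibitor, a lower number a stronger inhibitor), compound 1 (`COc1cc(C(=O)c2cn(-c3ccccc3)cc2-c2ccccc2F)cc(OC)c1OC`) gives 30 nM and compound 2 (`COc1cc(C(=O)c2cn(-c3ccccc3)cc2-c2cccc(C)c2)cc(OC)c1OC`) gives 450 nM, so compound 2 holds the higher of the two numbers. The next structure, compound 3 (`COc1cc(C(=O)c2cn(-c3ccccc3)cc2-c2cccc(F)c2)cc(OC)c1OC`), is compound 2 with fluoro in place of methyl on an aromatic carbon, meta to a large group: fluoro in place of methyl on an aromatic carbon. For the measured compounds named here, only one measured step bears on this change: a 15-fold higher number from compound 1 to compound 2 (1.18 log units; beyond the scatter), a large step beyond the scatter. That step alters both the group and its place, so it isolates neither. Compound 3 carries fluoro like compound 1 at 30 nM, but keeps the place of the methyl in compound 2 at 450 nM. Part of that step is therefore expected to be recovered, towards a lower number in this assay. The expected change is a 3.0-fold lower number from compound 2 to compound 3 (0.48 log units; beyond the scatter). For compound 3 the estimated value is 150 nM, with an expected range of 40 nM to 500 nM.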

Compound 3, half-maximal inhibitory concentration: 57 nM
Compound 3: middle estimate off by 2.6-fold (0.42 log units), on the high side, and the stated range covers the measured number.
By their numbers in this assay, from the lowest: compounds 1 and 3 (each within the scatter of the next); then compound 2.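

In this assay, with the place on the ring held fixed, fluoro in place of methyl meta to a large group is a real change (a 7.9-fold lower number from compound 2 to compound 3 (0.90 log units; beyond the scatter)). That separates what the earlier step could not: most of the gap between compound 1 and compound 2 follows the swap of methyl for fluoro, not the shift of place. The fluoro itself can shift, as 3-fluorophenyl in place of 2-fluorophenyl gives no readable difference (a 1.9-fold higher number from compound 1 to compound 3 (0.28 log units; within the scatter)). Nothing at hand gives a cause for either step.

The compounds shown leave open whether a methyl at the place of the fluoro in compound 1 would behave as it does in compound 2. They also leave open how far this place tolerates other groups, such as chloro, methoxy or an amine.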